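The compounds below may be only part of what the source reports. "The series", "measured", "known", "first", "only" and "open" are said of these compounds alone.

In an assay on Prostate gland for inhibition of steroid 5-alpha-reductase (Rattus norvegicus) (a lower number here means a stronger inhibitor, a higher number a weaker inhibitor), three compounds that share one core have been measured, differing only in the group on the aromatic nitrogen of the five-membered ring. Compound 1 `CCCCn1ccc2cc(/C(C)=C/C(=O)Nc3ccccc3OCCCC(=O)O)ccc21` gives 43 nM. Compound 2 `C/C(=C\C(=O)Nc1ccccc1OCCCC(=O)O)c1ccc2c(ccn2CC(C)C)c1` gives 160 nM. Compound 3 `CCCC(C)n1ccc2cc(/C(C)=C/C(=O)Nc3ccccc3OCCCC(=O)O)ccc21` gives 7.8 nM, the lowest of the three: compound 1 is nearest and compound 2 furthest, and since both a 5.5-fold lower number from compound 1 to compound 3 (0.74 log units; beyond the scatter) and a 21-fold lower number from compound 2 to compound 3 (1.31 log units; beyond the scatter) lie beyond the scatter, compound 3 is the strongest inhibitor of the set. Compound 4 `C/C(=C\C(=O)Nc1ccccc1OCCCC(=O)O)c1ccc2c(ccn2Cc2ccc(C(C)(C)C)cc2)c1` has not yet been measured. Its change from compound 3 is 4-(tert-butyl)benzyl in place of 1-methylbutyl on an aromatic nitrogen. Every measured step touches the same nitrogen: a 3.7-fold higher number from compound 1 to compound 2 (0.57 log units; beyond the scatter), a 5.5-fold lower number from compound 1 to compound 3 (0.74 log units; beyond the scatter) and a 21-fold lower number from compound 2 to compound 3 (1.31 log units; beyond the scatter). The step that put methyl in place of hydrogen on the saturated chain carbon bound to the aromatic nitrogen lowered the number, while compound 1 and compound 2, whose chains carry no such methyl, gave the higher numbers. Among the compounds with values here, the 4-(tert-butyl)benzyl group likewise carries no methyl on that carbon, but no measured step brings an aromatic ring to this place, so the size of its effect cannot be read from the data. The expectation is therefore that compound 4 gives a higher number than compound 3, a step of about a 5.1-fold higher number from compound 3 to compound 4 (0.71 log units; beyond the scatter) in this assay. The estimate for compound 4 in this assay is 40 nM, with a range from 10 nM to 160 nM.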

Compound 4, half-maximal inhibitory concentration: 170 nM
The estimate for compound 4 lay 4.3-fold (0.63 log units) below the measured number, and the stated range ends below it.
By their numbers in this assay, from the lowest: compound 3; then compound 1; then compounds 2 and 4 (each within the scatter of the next).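

In this assay, within the data shown here, the 4-(tert-butyl)benzyl group puts an aromatic ring on this nitrogen for the first time, with 11 heavy atoms in place of the 5 of 1-methylbutyl, and the change gives a 22-fold higher number from compound 3 to compound 4 (1.34 log units; beyond the scatter). Against the open-chain groups without the methyl on the carbon bound to the nitrogen, the picture is mixed: a 1.1-fold higher number from compound 2 to compound 4 (0.03 log units; within the scatter) stays within the scatter, while a 4.0-fold higher number from compound 1 to compound 4 (0.60 log units; beyond the scatter) lies beyond it. The ring-bearing group therefore leaves compound 3 as the strongest inhibitor of the four, with a result that cannot be told apart from the isobutyl group, and nothing shown here explains these differences.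

The compounds shown leave open whether the step up from compound 3 belongs to the benzyl ring itself or to its tert-butyl group, which a plain benzyl group on the same nitrogen would separate. They also leave open whether a 1-phenylethyl group, which carries both an aromatic ring and a methyl on the carbon bound to the nitrogen, would behave more like compound 3 or more like compound 4.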